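A few compounds are considered here, and "the series" means these few. Any claim that something is new, unique, unknown or untested is made for them only; others in the source may bear on it.

Among the measured compounds shown here, compound 3 `CO[C@@H]1CC=C2N(c3ccc(C)cc3)C(=O)C[C@]2(c2ccccc2)O1` stands, on the numbers so far, at the low end of a very narrow field. In a functional assay on SK-BR-3 cells (Homo sapiens) for cytotoxicity, read by sulforhodamine B assay, with a stated time of 48 h (a lower number here means a stronger inhibitor, a higher number a weaker inhibitor), compound 3 gives 1100 nM; compound 1 `COc1cc(OC)cc(N2NC3=CC[C@@H](OC)O[C@@]3(c3ccccc3)CCC2=O)c1` gives 1200 nM in this assay, and compound 2 `CO[C@@H]1CC=C2NN(c3c[nH]c4ccccc34)C(=O)CC[C@]2(c2ccccc2)O1` gives 1200 nM, so the three values lie within the scatter of one another and no order among them can be read.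

Compound 4 `CO[C@@H]1CC=C2N(c3c[nH]c4ccccc34)C(=O)C[C@]2(c2ccccc2)O1` differs from compound 3 in a single place: 1H-indol-3-yl in place of 4-methylphenyl on an amide-type nitrogen in a ring. For the measured compounds named here, the one measured step that bears on this exchange is the one from compound 1 to compound 2, where the same indol-3-yl group entered on the same amide-type nitrogen, there in place of 3,5-dimethoxyphenyl; that step gave no change at the digits printed from compound 1 to compound 2 (within the scatter). Going by the values given here, the departing group in the present case, 4-methylphenyl, is not the same as the departing group in that step, so the parallel is partial, but it is the only guide the data offer.

On that basis the step from compound 3 to compound 4 is expected to be no change at the digits printed from compound 3 to compound 4 (within the scatter), no change beyond the scatter. Compound 4 is therefore estimated at 1100 nM in this assay, within a range of 500 nM to 2500 nM.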

Compound 4, half-maximal inhibitory concentration: 2300 nM
Compound 4: middle estimate off by 2.1-fold (0.32 log units), on the low side; the measured number falls inside the stated range.
By their numbers in this assay, from the lowest: compounds 3, 1, 2 and 4 (each within the scatter of the next, the first and the last beyond it).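

In this assay the exchange of 4-methylphenyl for 1H-indol-3-yl on the amide-type nitrogen gives a 2.1-fold higher number from compound 3 to compound 4 (0.32 log units; beyond the scatter) and so, unlike the earlier step, moves the number beyond the scatter, showing that on this core the group at this position can register in the assay, though modestly. When 1H-indol-3-yl entered on the amide-type nitrogen of the different core shared by compound 1 and compound 2, replacing 3,5-dimethoxyphenyl, the result was no change at the digits printed from compound 1 to compound 2 (within the scatter), so the same entering group did not give the same outcome in the two pairs, which differ in both their core and their departing group. No measured evidence is available to account for this step or for the difference between the two pairs.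

The compounds shown leave open whether the step follows the indole nitrogen and its hydrogen or the larger group as a whole, a question that naphthalen-2-yl at the same place could address. They also leave open whether 4-methylphenyl on the core of compound 1 would separate from 1H-indol-3-yl there, and so which of the two differences between the pairs matters.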